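This account rests on a few compounds, and the source may have more. Where it says the series, first, only, none or still open, it means among the compounds named here.

Of the compounds shown here, two of the shared core have been measured so far. Compound 1 `O=C(N/N=C/c1cc(I)cc(I)c1O)c1ccc(I)cc1` in a functional assay on HepG2 cells (Homo sapiens) for cytotoxicity, with a stated time of 24 h (a higher number here means a weaker inhibitor, a lower number a stronger inhibitor), gives 31800 nM. Compound 2 `O=C(N/N=C/c1cc(I)c(O)c(I)c1)c1ccccc1` in this assay gives 191000 nM, the higher of the two numbers, and its gap to compound 1 lies beyond the scatter. Compound 3 `O=C(N/N=C/c1cc(I)c(O)c(I)c1)c1ccc(C(F)(F)F)cc1` differs from compound 2 by trifluoromethyl in place of hydrogen on an aromatic carbon. For the measured compounds named here, no measured pair shows this change, so the direction rests only on the two values above. A modest downward step a 2.7-fold lower number from compound 2 to compound 3 (0.44 log units; beyond the scatter) is expected in this assay. Compound 3 is estimated at 70000 nM, within 20000 nM to 200000 nM.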

Compound 3, half-maximal inhibitory concentration: 57400 nM
For compound 3 the middle estimate is 1.2-fold (0.09 log units) above the measured one, within the range that was stated.
By their numbers in this assay, from the lowest: compounds 1 and 3 (each within the scatter of the next); then compound 2.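

In this assay, for the compounds shown here, trifluoromethyl in place of hydrogen on this aromatic carbon, para to a large group, gives a 3.3-fold lower number from compound 2 to compound 3 (0.52 log units; beyond the scatter) and provides the first single-place step. This position therefore tolerates a group larger than hydrogen, and the number moves downward by more than the scatter. No measurement available here bears on the reason for this step.

As far as these compounds go, whether a nitrile, an amine or a carboxylic acid on the same carbon moves the number in the same direction remains open. A single step also leaves open whether the change would carry over to the core of compound 1.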